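A few compounds are considered here, and "the series" means these few. Any claim that something is new, unique, unknown or untested is made for them only; others in the source may bear on it.

Compound 1 `C=CC1=C(C(=O)NCCC)C(c2ccc(F)cc2)OC1` was tested in a functional assay on SW480 cells (Homo sapiens) for cytotoxicity, read by MTT assay, with a stated time of 24 h (a higher number here means a weaker inhibitor, a lower number a stronger inhibitor), and gave only a limit, > 100000 nM, so its true value is not known. Compound 2 `C=CC1=C(C(=O)NCCCCC)C(c2ccc(Cl)c(Cl)c2)OC1` gave 27500 nM in this assay. Compound 3 `C=CC1=C(C(=O)Nc2ccccc2)C(c2ccc(F)cc2)OC1` differs from compound 1 by one change, (phenyl in place of propyl on an amide-type nitrogen). Within the data shown here, no measured pair shows how this change acts, and compound 1 stands at the limit of > 100000 nM in this assay, at which 1 of the 2 values shown sits, so only a loose expectation can be given. Compound 3 is expected to move by an at least 1.4-fold lower number from compound 1 to compound 3 (0.15 log units; that floor lies within the scatter) in this assay, toward the weaker end. The estimated value of compound 3 is 70000 nM, with a range from 20000 nM to 250000 nM.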

Compound 3, half-maximal inhibitory concentration: > 100000 nM
Compound 3: only a limit was reported (the forecaster's own chance of this, stated with the estimate: 50%); middle value at least 1.4-fold (0.15 log units) away from the limit.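

In this assay compound 3 gives > 100000 nM, which is a limit. Compound 1 is also reported only as a limit, and the step between the two cannot be read. Going by these compounds, whether phenyl in place of propyl on the amide-type nitrogen shifts the value at all stays open.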